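Swapping bromo for isopropoxy on a fluorinated core

The compounds below may be only part of what the source reports. "The series", "measured", "known", "first", "only" and "open" are said of these compounds alone.

This small set of three alcohols was tested in an ADME assay on L6 cells (Rattus norvegicus) for cytotoxicity, read by resazurin assay, with a stated time of 72 h; on this read-out lower numbers stand for stronger inhibition and higher numbers for weaker inhibition. Compound 1 `CC(C)Oc1ccc(C(O)(c2ccc(C(F)(F)F)cc2)c2cccnc2)cc1` gives 47600 nM. Compound 2 `OC(c1ccc(Br)cc1)(c1ccc(C(F)(F)F)cc1)c1cccnc1` gives 54700 nM in this assay. Compound 3 `OC(c1ccc(Cl)cc1)(c1cccnc1)c1ccc(Br)cc1F` gives 79200 nM in this assay, and all three numbers lie within the scatter of one another.

One pairwise comparison exists among the measured compounds: isopropoxy in place of bromo on an aromatic carbon. That exchange made a 1.1-fold lower number from compound 2 to compound 1 (0.06 log units; within the scatter).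

The unmeasured compound 4 `CC(C)Oc1ccc(C(O)(c2ccc(Cl)cc2)c2cccnc2)c(F)c1` arises from compound 3 by the same kind of change: isopropoxy in place of bromo on an aromatic carbon. The place lines differ in one respect: on the core of compound 3 the aromatic carbon carrying the change is also meta to a fluoro group (1 heavy atom), which compound 2 lacks. The difference between the two cores is not broken down here.

Because the earlier step of a 1.1-fold lower number from compound 2 to compound 1 (0.06 log units; within the scatter) stayed within the scatter, a step of similar size, a 1.1-fold lower number from compound 3 to compound 4 (0.04 log units; within the scatter), is expected in this assay. Compound 4 is thus estimated at 72000 nM, with a plausible range from 40000 nM to 130000 nM.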

Compound 4, half-maximal inhibitory concentration: 58200 nM
For compound 4 the middle estimate is 1.2-fold (0.09 log units) above the measured one; the measured number falls inside the stated range.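

In this assay, replacing bromo with isopropoxy gives a 1.4-fold lower number from compound 3 to compound 4 (0.13 log units; within the scatter), so this step, like the earlier one, stays inside the usual scatter. The two steps agree: the same change on two cores in this assay, a 1.1-fold lower number (0.06 log units; within the scatter) from compound 2 to compound 1 and a 1.4-fold lower number (0.13 log units; within the scatter) from compound 3 to compound 4, 1.2-fold (0.07 log units) apart, within the scatter of two such steps. Among the compounds shown here, on these two cores the change carries over without a visible difference, even though on the second core the changed carbon is also meta to a fluoro group; however, steps this small show only that neither core gives a step beyond the scatter, and two cores are too few to make a rule for the whole series.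

The compounds shown leave open how an amine, a carboxylic acid or a longer chain in the same place would read in this assay. They also leave open whether the step would stay this small on a core that carries neither trifluoromethyl nor chloro on its other aromatic ring.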